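Chlorophenyl for methoxyphenyl on the amino nitrogen

The compounds below may be only part of what the source reports. "The series", "measured", "known", "first", "only" and "open" are said of these compounds alone.

Compound 1 `CC(C)c1ccc(-c2nc(SCc3cn(CC(=O)NC(=O)Nc4ccccn4)nn3)nc(Nc3cccc(Cl)c3)c2C#N)cc1`: 18000 nM
Compound 2 `COc1ccc(Nc2nc(SCc3cn(CC(=O)NC(=O)Nc4ccccn4)nn3)nc(-c3ccc(C(C)C)cc3)c2C#N)cc1`: > 64000 nM
Compound 3 `COc1ccc(Nc2nc(SCc3cn(CC(=O)NC(=O)Nc4ccccn4)nn3)nc(-c3ccc(C)cc3)c2C#N)cc1`: 23400 nM

In a functional assay on MCF7 cells (Homo sapiens) for inhibition, read by MTT assay, with a stated time of 72 h (a lower number here means a stronger inhibitor, a higher number a weaker inhibitor), compound 1 gives 18000 nM. Compound 2 reaches only the limit of this assay, > 64000 nM, and no number. Compound 3 gives 23400 nM in this assay, a value that sits within the usual scatter of the value of compound 1, so the two cannot be ranked against each other. Two of the three values are numbers and one, that of compound 2, is a limit (the limit of > 64000 nM in this assay, at which 1 of the 3 values shown sits).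

Compound 4 `Cc1ccc(-c2nc(SCc3cn(CC(=O)NC(=O)Nc4ccccn4)nn3)nc(Nc3cccc(Cl)c3)c2C#N)cc1` is not yet measured. It differs from compound 3 in one place: 3-chlorophenyl in place of 4-methoxyphenyl on a nitrogen on an aromatic ring. The same exchange, taken in the opposite direction, has been measured once, as the step of an at least 3.5-fold higher number from compound 1 to compound 2 (0.55 log units; beyond the scatter), an at least modest weakening on going to the methoxyphenyl. The other step known, an at least 2.7-fold lower number from compound 2 to compound 3 (0.43 log units; beyond the scatter), concerns the group on the aromatic carbon and is already shared by compound 3 and compound 4.

Reversing the measured exchange, the writer expects compound 4 to show a lower number than compound 3, a step of a 3.3-fold lower number from compound 3 to compound 4 (0.52 log units; beyond the scatter) in this assay. Compound 4 is thus estimated at 7000 nM, with a range from 2500 nM to 20000 nM.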

Compound 4, half-maximal inhibitory concentration: 14900 nM
The estimate for compound 4 lay 2.1-fold (0.33 log units) below the measured number; the range from low to high includes it.
By their numbers in this assay, from the lowest: compounds 4, 1 and 3 (each within the scatter of the next). At a limit, above all of these: compound 2.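

In this assay, the exchange on the nitrogen, with methyl on the aromatic carbon, gives a 1.6-fold lower number from compound 3 to compound 4 (0.20 log units; within the scatter), so on this core the values do not separate 3-chlorophenyl from 4-methoxyphenyl, and the clear weakening seen earlier with isopropyl on the aromatic carbon is not repeated: the same change on two cores in this assay, an at least 3.5-fold higher number (0.55 log units; beyond the scatter) from compound 1 to compound 2 and a 1.6-fold higher number (0.20 log units; within the scatter) from compound 4 to compound 3; the limit leaves it open whether they differ. Methyl in place of isopropyl, with 3-chlorophenyl on the nitrogen, gives a 1.2-fold lower number from compound 1 to compound 4 (0.08 log units; within the scatter), so this change also leaves the values inseparable on the second core: the same change on two cores in this assay, an at least 2.7-fold lower number (0.43 log units; beyond the scatter) from compound 2 to compound 3 and a 1.2-fold lower number (0.08 log units; within the scatter) from compound 1 to compound 4; the limit leaves it open whether they differ. Among these compounds, both changes thus exceed the scatter only in the steps that involve compound 2, which is the one compound held at a limit rather than a number: the limit of > 64000 nM in this assay, at which 1 of the 4 values shown sits.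

The 4-methoxyphenyl and 3-chlorophenyl groups differ both in their substituent and in its place on the ring, and the compounds shown leave open which of the two matters. They also leave open how an unsubstituted phenyl, or an amine such as morpholine in place of the whole arylamino group, would read in this assay.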